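This account rests on a few compounds, and the source may have more. Where it says the series, first, only, none or still open, it means among the compounds named here.

Compound 1 `CS(=O)(=O)NNc1nonc1/C(=N/O)Nc1ccc(F)c(Br)c1` gives 609 nM in an assay on isolated protein for inhibition of Indoleamine 2,3-dioxygenase 1 (Homo sapiens), read by fluorescence, with a stated time of 60 min; on this read-out higher numbers stand for weaker inhibition and lower numbers for stronger inhibition. Compound 2 `[O-][S+]1CC(Nc2nonc2/C(=N/O)Nc2ccc(F)c(Br)c2)C1` gives 212 nM in this assay, and compound 3 `NS(=O)(=O)CCNc1nonc1/C(=N/O)Nc1ccc(F)c(Br)c1` gives 71 nM. The steps among them are all modest: a 2.9-fold lower number from compound 1 to compound 2 (0.46 log units; beyond the scatter), an 8.6-fold lower number from compound 1 to compound 3 (0.93 log units; beyond the scatter) and a 3.0-fold lower number from compound 2 to compound 3 (0.48 log units; beyond the scatter). Compound 3 thus stands lowest of the three, with compound 2 nearest and compound 1 furthest.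

Compound 4 `O=S(=O)(CCNc1nonc1/C(=N/O)Nc1ccc(F)c(Br)c1)N1CCC1` differs from compound 3 by azetidin-1-yl in place of amino on a sulfonyl sulfur. Going by the values given here, none of the measured steps alters a substituent on the sulfonyl sulfur; the steps from compound 1 and compound 2 concern the group on the nitrogen on the aromatic ring, so they bear only loosely on this change. The data therefore give no firm direction. Compound 4 is expected to remain close to compound 3, with at most a small step in this assay, and the estimated step is a 1.7-fold higher number from compound 3 to compound 4 (0.23 log units; within the scatter). Compound 4 is estimated at 120 nM in this assay, in a range from 40 nM to 400 nM.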

Compound 4, half-maximal inhibitory concentration: 191 nM
Compound 4: middle estimate off by 1.6-fold (0.20 log units), on the low side, and the stated range covers the measured number.
By their numbers in this assay, from the lowest: compound 3; then compounds 4 and 2 (each within the scatter of the next); then compound 1.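

In this assay, going by these compounds alone, azetidin-1-yl in place of amino on a sulfonyl sulfur gives a 2.7-fold higher number from compound 3 to compound 4 (0.43 log units; beyond the scatter), which shows that this place, untouched by the earlier steps, responds to its substituent. The full group on the nitrogen on the aromatic ring then reads as a 1.1-fold lower number from compound 2 to compound 4 (0.05 log units; within the scatter), within the scatter, and as a 3.2-fold lower number from compound 1 to compound 4 (0.50 log units; beyond the scatter), so 2-((azetidin-1-yl)sulfonyl)ethyl keeps a lead over methanesulfonamido but loses the one that 2-sulfamoylethyl held over the group of compound 2. No supporting evidence is available to explain this step.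

The compounds shown leave open whether the step goes with the ring or with the loss of the amino hydrogens. A methylamino or dimethylamino group on the sulfonyl sulfur would separate the two, and a pyrrolidin-1-yl group would show how the step changes with a larger ring.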